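The source may report more compounds than this note shows. Statements on the series, on what has been measured and on what is new or still open speak of the compounds shown alone.

Compound 1 `Cc1ccccc1-c1nnc(NN)s1` gives in a functional assay on the whole organism with Mus musculus as the target, in the maximal electroshock model, with a stated time of 1 h; a higher number here means that more compound is needed for the effect, a lower number that less compound is needed > 100 mg/kg, which is a limit of the assay rather than a number.
Compound 2 `Cc1ccccc1-c1nnc(N(N)c2ccccc2)s1` gives in this assay > 100 mg/kg, again a limit of the assay.

Both measured values sit at the limit of > 100 mg/kg in this assay, at which 2 of the 2 values shown sit, so compound 1 stands at a limit and nowhere else on this scale; no number places it. Among the measured compounds shown here, the single measured step, phenyl in place of hydrogen on a nitrogen on an aromatic ring, reads a step that the two limits leave unreadable from compound 1 to compound 2, and the two limits leave its size unreadable.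

Compound 3 `Cc1ccccc1-c1nnc(NNC2CCCC2)s1` differs from compound 1 by cyclopentyl in place of hydrogen on an amine nitrogen. For the measured compounds named here, nothing measured bears directly on a cyclopentyl group; the step from compound 1 to compound 2 puts a phenyl ring on a nitrogen and leaves the value at the limit, and that is the only guide available. The expected outcome is therefore that compound 3 also sits at or near the limit, with the step that the limit leaves unreadable from compound 1 to compound 3 expected to stay within the scatter. The estimate for compound 3 in this assay is 150 mg/kg, within a range from 60 mg/kg to 400 mg/kg.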

Compound 3, dose for half-maximal effect: > 100 mg/kg
Compound 3 was reported as a limit; the forecaster's own chance of this, stated with the estimate: 75%; the middle value lies beyond the limit too.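

The step from compound 1 to compound 3 cannot be read, and neither can any other step among these compounds, because every value is a limit rather than a number: the limit of > 100 mg/kg in this assay, at which 3 of the 3 values shown sit.

The compounds shown leave open what dose of each gives the half-maximal effect in this assay, and whether phenyl or cyclopentyl in place of hydrogen changes that dose at all.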